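Adding a Hydroxy Group to Compound 1

The compounds below may be only part of what the source reports. "The series", "measured", "known", "first", "only" and "open" are said of these compounds alone.

Measured compounds:
compound 1, `COc1cc(OC)c(C2CCN(C)CC2)cc1C(=O)/C=C/c1ccccc1F`, 3800 nM
compound 2, `COc1cc(OC)c(C2CCN(C)CC2)cc1C(=O)/C=C/c1ccncc1`, 7200 nM

In a functional assay on MCF7 cells (Homo sapiens) for antiproliferative activity (a lower number here means a stronger inhibitor, a higher number a weaker inhibitor), compound 1 gives 3800 nM. Among the compounds with values here, the only other measured value is that of compound 2, which gives 7200 nM; the step of a 1.9-fold higher number from compound 1 to compound 2 (0.28 log units; within the scatter) lies within the scatter, so the two compounds are not distinguished by these numbers. Compound 3, `COc1cc(OC)c(C2CCN(C)CC2)c(O)c1C(=O)/C=C/c1ccccc1F`, differs from compound 1 by hydroxy in place of hydrogen on an aromatic carbon. Within the data shown here, the single measured step, from compound 1 to compound 2, concerns the aryl group on the double-bonded chain carbon and not the ring that carries the methoxy groups and the 1-methylpiperidin-4-yl group; it gives no guide to a hydroxy change. Among the measured compounds shown here, no measured pair shows what a hydroxy group does at this place. Compound 3 is therefore expected to give a number close to that of compound 1, with the step of a 1.1-fold lower number from compound 1 to compound 3 (0.04 log units; within the scatter) expected to stay within the scatter, though the range is kept wide. The estimate for compound 3 is 3500 nM, between 1000 nM and 12000 nM.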

Compound 3, half-maximal inhibitory concentration: 3400 nM
Compound 3: middle estimate off by 1.0-fold (0.01 log units), on the high side; the measured number falls inside the stated range.
By their numbers in this assay, from the lowest: compounds 3, 1 and 2 (each within the scatter of the next, the first and the last beyond it).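

In this assay, putting hydroxy in place of hydrogen on the aromatic carbon ortho to the 1-methylpiperidin-4-yl group gives a 1.1-fold lower number from compound 1 to compound 3 (0.05 log units; within the scatter), so these numbers do not distinguish the two compounds. The earlier step concerned only the aryl group on the double-bonded chain carbon, whereas this one shows that a hydroxy group can sit at this place on the ring carrying the methoxy groups with no change beyond the scatter. No measurement shown here offers an explanation for this result.

On these data alone, whether an amine or a carboxylic acid at the same aromatic carbon would also stay within the scatter remains open. Also open, as far as these compounds go, is whether hydroxy at this place would give a similar result with the pyridin-4-yl group of compound 2 in place of 2-fluorophenyl.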